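The source may report more compounds than this note shows. Statements on the series, on what has been measured and on what is new or still open speak of the compounds shown alone.

Measured so far in an assay on isolated protein for inhibition of phosphodiesterase 4A (Sus scrofa); on this read-out higher numbers stand for weaker inhibition and lower numbers for stronger inhibition:

- compound 1, `COc1ccc(C(=O)Nc2c(F)cccc2Cl)cc1OC1CCCC1`: 240 nM
- compound 2, `CCCCOc1cc(C(=O)Nc2c(F)cccc2F)ccc1OC`: 300 nM
- compound 3, `COc1ccc(C(=O)Nc2c(Cl)cccc2Cl)cc1OC1CC2CCC1C2`: 10 nM

Compound 1 sits second highest of the three numbers. Compound 2 is its nearest neighbour, and the two values lie within the scatter of each other, so nothing separates them on this read-out. Compound 3 is the furthest away, with a much lower number that lies beyond the scatter; compound 3 differs from compound 1 in more than one place, so that gap cannot be assigned to any single change.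

Compound 4, `COc1ccc(C(=O)Nc2c(C)nsc2Br)cc1OC1CCCC1`, has not been measured in this assay. It differs from compound 1 in one place: 5-bromo-3-methyl-1,2-thiazol-4-yl in place of 2-chloro-6-fluorophenyl on an amide-type nitrogen. Among the measured compounds shown here, no measured pair in the set isolates an exchange of this kind on the amide-type nitrogen, so there is no step to lean on; the expectation rests on compound 1 alone.

For the measured compounds named here, with no precedent, the step from compound 1 to compound 4 is expected to be small, a 1.3-fold higher number from compound 1 to compound 4 (0.10 log units; within the scatter), not clearly beyond the scatter in either direction. Compound 4 is therefore estimated at 300 nM in this assay, within a range of 80 nM to 1200 nM that allows for the unknown effect of the exchange.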

Compound 4, half-maximal inhibitory concentration: 500 nM
The estimate for compound 4 lay 1.7-fold (0.22 log units) below the measured number, within the range that was stated.
By their numbers in this assay, from the lowest: compound 3; then compounds 1, 2 and 4 (each within the scatter of the next, the first and the last beyond it).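

Compound 4 gives the series its first step that can be read at a single place: at the amide-type nitrogen, 5-bromo-3-methyl-1,2-thiazol-4-yl in place of 2-chloro-6-fluorophenyl gives a 2.1-fold higher number from compound 1 to compound 4 (0.32 log units; beyond the scatter) in this assay on the core of compound 1. The step is modest, so for this pair the six-membered aromatic ring of carbon only can give way to a five-membered aromatic ring with 2 hetero atoms at a limited cost, with compound 4 still reading 500 nM in this assay. No available evidence bears on what lies behind this step.

The exchange alters the ring size, the hetero atoms, the halogen and the methyl group at once, so this one step cannot divide its effect among those parts. Among the compounds shown here, also open is how an unsubstituted phenyl, a pyridine ring carrying the same halogens, or a thiazole without the bromine would read at this amide-type nitrogen, and whether the step would hold on a core carrying a different ether group from the one in compound 1.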